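Fluoro for Methyl on Two Compounds at the Assay Limit

The compounds below may be only part of what the source reports. "The series", "measured", "known", "first", "only" and "open" are said of these compounds alone.

Compound 1, `C/C(=C\c1nc(-c2ccccc2)cs1)C(N)=O`: in a functional assay on BGC-823 cells (Homo sapiens) for cytotoxicity, read by CCK-8 assay, with a stated time of 24 h (a higher number here means a weaker inhibitor, a lower number a stronger inhibitor), compound 1 gives > 50000 nM.
Compound 2, `C/C(=C\c1nc(-c2ccc(C)cc2)cs1)C(N)=O`: in this assay compound 2 gives > 50000 nM.

The value for compound 1 is a limit of the assay, not a measured number. The value for compound 2 is likewise a limit. Where compound 2 stands can therefore be said only loosely: its cytotoxicity against these cells is too weak to be read. Among the measured compounds shown here, the single step between the measured compounds, a step that the two limits leave unreadable from compound 1 to compound 2, cannot be sized, since the two limits hide any difference; the limit of > 50000 nM in this assay, at which 2 of the 2 values shown sit, makes this plain.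

Compound 3, `C/C(=C\c1nc(-c2ccc(F)cc2)cs1)C(N)=O`, has not yet been tested. The change from compound 2 is fluoro in place of methyl on an aromatic carbon. For the measured compounds named here, no measured step bears on this change with a readable size, so the expectation rests only on the fact that compound 1 and compound 2 both sit at the limit. The step from compound 2 to compound 3 is expected to be a step that the limit leaves unreadable from compound 2 to compound 3, that is, none beyond the scatter. Compound 3 is therefore estimated at 100000 nM, with a range from 40000 nM to 300000 nM, and most likely another limit.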

Compound 3, half-maximal inhibitory concentration: > 50000 nM
Compound 3 gave a limit, no number (the forecaster's own chance of this, stated with the estimate: 85%); the middle value is on the limit's open side.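

Compound 3 gives only a limit of the assay in this assay, not a number, so no step among compound 1, compound 2 and compound 3 can be read: the limit of > 50000 nM in this assay, at which 3 of the 3 values shown sit.

The compounds shown leave open whether any change to the shared core can bring cytotoxicity against these cells into a readable range.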